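The compounds below may be only part of what the source reports. "The series", "measured", "known", "first", "only" and "open" are said of these compounds alone.

Measured so far:
Compound 1, `Cc1nc(N)c2c(-c3cccs3)cn([C@@H]3O[C@H](CO)[C@@H](O)[C@H]3O)c2n1`. In a functional assay on K562 cells (Homo sapiens), read by MTT assay, with a stated time of 72 h (a higher number here means a weaker inhibitor, a lower number a stronger inhibitor), compound 1 gives > 20000 nM, which is a limit of the assay.
Compound 2, `Cc1nc(N)c2c(-c3cc4ccccc4o3)cn([C@@H]3O[C@H](CO)[C@@H](O)[C@H]3O)c2n1`. In this assay compound 2 gives 4990 nM.
Compound 3, `CN(C)c1ncnc2c1c(-c1cccs1)cn2[C@@H]1O[C@H](CO)[C@@H](O)[C@H]1O`. In this assay compound 3 gives > 20000 nM, again a limit of the assay.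

Compounds 1 and 3 share a sugar and a fused bicyclic core but differ in the substituents on that core; the difference between the two cores is not broken down here. Among the compounds with values here, two of the three values sit at the limit of > 20000 nM in this assay, at which 2 of the 3 values shown sit, so the only sized step comes from compound 1 to compound 2: 1-benzofuran-2-yl in place of thiophen-2-yl on an aromatic carbon, giving an at least 4.0-fold lower number from compound 1 to compound 2 (0.60 log units; beyond the scatter).

Compound 4, `CN(C)c1ncnc2c1c(-c1cc3ccccc3o1)cn2[C@@H]1O[C@H](CO)[C@@H](O)[C@H]1O`, is not yet measured. It arises from compound 3 by the same change, (1-benzofuran-2-yl in place of thiophen-2-yl on an aromatic carbon), and the place lines of the two changes read alike. The expectation rests on one pair only. Because compound 3 shows > 20000 nM, only a limit, the starting point is itself uncertain; the step is expected to be an at least 2.5-fold lower number from compound 3 to compound 4 (0.39 log units; beyond the scatter). Compound 4 is estimated at 8000 nM, with a range from 2000 nM to 30000 nM, in this assay.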

Compound 4, half-maximal inhibitory concentration: > 20000 nM
Compound 4 was reported as a limit; the forecaster's own chance of this, stated with the estimate: 35%; middle value at least 2.5-fold (0.39 log units) from the limit.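

No step can be read from compound 3 to compound 4, because both results are limits of the assay and not numbers: the limit of > 20000 nM in this assay, at which 3 of the 4 values shown sit.

The compounds shown leave open whether 1-benzofuran-2-yl in place of thiophen-2-yl lowers the number on the core of compound 3, as it does on the core of compound 1.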